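A few compounds are considered here, and "the series" means these few. Any claim that something is new, unique, unknown or untested is made for them only; others in the source may bear on it.

Measured in an ADME assay on BHK cells (Mesocricetus auratus) for cytotoxicity, read by MTT assay, with a stated time of 96 h; on this read-out lower numbers stand for higher toxicity in this test and higher numbers for lower toxicity in this test:
compound 1 `COc1ccc(-c2nc3cc(C(F)(F)F)ccc3[nH]2)c(OC)c1`: > 100000 nM (a limit, not a number)
compound 2 `COc1ccc(-c2nc3cc(C(F)(F)F)ccc3[nH]2)c(OC)c1OC`: 32000 nM
compound 3 `COc1ccc(-c2nc3cc(C(F)(F)F)ccc3[nH]2)c([N+](=O)[O-])c1`: 100000 nM

In this assay compound 1 stands at the limit of > 100000 nM in this assay, at which 1 of the 3 values shown sits. Compound 4 `COc1ccc(-c2nc3cc([N+](=O)[O-])ccc3[nH]2)c(OC)c1` differs from compound 1 in one place: nitro in place of trifluoromethyl on an aromatic carbon. In words, this is nitro in place of trifluoromethyl on an aromatic carbon. Within the data shown here, no measured step changes that carbon, so the evidence is indirect. One guide is an at least 3.1-fold lower number from compound 1 to compound 2 (0.49 log units; beyond the scatter), a change beyond the scatter but of a different kind. The closer guide is a number no higher from compound 1 to compound 3 (the limit leaves the size open), which also brings in a nitro group, though at another place and with its size left open by the limit. Neither step points to a higher number, so a modest move towards a lower number is expected, and a result at the limit remains possible. The expected step is an at least 1.6-fold lower number from compound 1 to compound 4 (0.22 log units; that floor lies within the scatter). For compound 4 the estimate is 60000 nM, with an expected range from 20000 nM to 100000 nM.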

Compound 4, half-maximal cytotoxic concentration: > 100000 nM
Compound 4 ended at the assay's limit; the forecaster's own chance of this, stated with the estimate: 35%; at least 1.6-fold (0.22 log units) between middle value and limit.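

In this assay, compound 1 and compound 4 both carry a limit rather than a number, so the step between them cannot be read: the limit of > 100000 nM in this assay, at which 2 of the 4 values shown sit.

The compounds shown leave open whether nitro in place of trifluoromethyl on an aromatic carbon changes the read-out at all.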